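Swapping a Pyridine Attachment Point on a Shared Core

A few compounds are considered here, and "the series" means these few. Any claim that something is new, unique, unknown or untested is made for them only; others in the source may bear on it.

Four compounds built on one shared core are considered here, all tested in a functional assay on T47D cells (Homo sapiens) for cytotoxicity, read by CCK-8 assay and cell counting, with a stated time of 2 days; a lower number here means a stronger inhibitor, a higher number a weaker inhibitor. Among the compounds with values here, compound 1 `Oc1cccc(-c2cc(-c3ccco3)nc(-c3ccccc3Cl)c2)c1` is the only one with a number in hand: in this assay compound 1 gives 2010 nM. Compound 2 `Oc1ccc(-c2cc(-c3ccncc3)nc(-c3ccc(Cl)cc3)c2)cc1` carries a pyridin-4-yl group and a 4-chlorophenyl group beside the hydroxyphenyl unit, but in this assay compound 2 gives "not determined" (no result reported). Compound 3 `Oc1cccc(-c2cc(-c3ccccn3)nc(-c3ccccc3Cl)c2)c1` likewise has no result, since in this assay compound 3 gives "not determined" (no result reported). So compound 2 stands nowhere on the numbers shown; it has no value to rank against compound 1.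

Compound 4 `Oc1ccc(-c2cc(-c3ccc(Cl)cc3)nc(-c3ccccn3)c2)cc1` has the same atoms as compound 2, joined differently: pyridin-2-yl in place of pyridin-4-yl on an aromatic carbon. Within the data shown here, with compound 2 unmeasured, no step can be computed, and nothing in the data says whether moving the pyridine attachment point should strengthen or weaken inhibition in this assay; the honest expectation is a change of no known direction, possibly none beyond the scatter.

Among the measured compounds shown here, the only anchor is compound 1 at 2010 nM. Compound 4 is therefore expected to land near 2500 nM, within a wide range from 500 nM to 12000 nM.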

Compound 4, half-maximal inhibitory concentration: 25900 nM
Beside the measured number, compound 4's estimate is 10-fold (1.02 log units) below it, and the stated range ends below it.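

No step can be read from compound 2 to compound 4: compound 4 gives 25900 nM and compound 2 shows no number to set against it. The compounds shown leave open whether pyridin-2-yl in place of pyridin-4-yl changes inhibition at all, and in which direction. No supporting data here bear on this result.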